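This account rests on a few compounds, and the source may have more. Where it says the series, first, only, none or still open, it means among the compounds named here.

In a functional assay on MCF7 cells (Homo sapiens) for inhibition, read by MTT assay, with a stated time of 48 h (a lower number here means a stronger inhibitor, a higher number a weaker inhibitor), two compounds have been measured so far:

Compound 1 `O=C(C=CNc1cc(-c2ccccc2)nn1-c1ccccc1)c1ccc(Br)cc1` gives 21700 nM
Compound 2 `Cc1ccc(-c2ccnc3c2c(-c2ccccc2)nn3-c2ccccc2)cc1` gives 5590 nM

Of these two numbers compound 1 has the higher, which makes it the weaker inhibitor. The gap that separates compound 1 from compound 2 lies beyond the usual scatter of repeat measurements. Not yet measured is compound 3 `O=C(C=CNc1cc(-c2ccccc2)nn1-c1ccccc1)c1ccc(F)cc1`, which differs from compound 1 in one place: fluoro in place of bromo on an aromatic carbon. This is fluoro in place of bromo on an aromatic carbon, turning 4-bromophenyl into 4-fluorophenyl. For the measured compounds named here, no measured pair shows what this swap does, so the only anchor is compound 1 (21700 nM). No step beyond the scatter is expected in this assay, and neither direction is favoured. The expected step is a 1.1-fold lower number from compound 1 to compound 3 (0.04 log units; within the scatter). Compound 3 is estimated at 20000 nM, with an expected range from 8000 nM to 50000 nM.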

Compound 3, half-maximal inhibitory concentration: 9180 nM
For compound 3 the middle estimate is 2.2-fold (0.34 log units) above the measured one; measured number inside the range.
By their numbers in this assay, from the lowest: compounds 2 and 3 (each within the scatter of the next); then compound 1.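

In this assay, fluoro in place of bromo gives a 2.4-fold lower number from compound 1 to compound 3 (0.37 log units; beyond the scatter), so this place on the ring responds to what it carries, even though the step is modest. The change is small: one heavy atom leaves and one enters, on an aromatic carbon para to a large group, with no ring, no charge and no hydrogen-bond donor or acceptor counted on either side. Nothing available accounts for the step, so it stands as an observation without an explanation.

A single pair cannot show whether the numbers follow any order among substituents here, and chloro, a methoxy group or an amine at the same place would begin to test that. Going by these compounds, whether the same swap gives a similar step on a different core also remains open.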